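The source may hold more compounds than are shown below. What is called first, only, known or untested is meant among the compounds shown, and "the series" means these compounds.

Measured compounds:
compound 1 `Cc1ccccc1NNC(=O)C1CCCCC1`, 174 nM in an in vitro functional assay on 1321-N1 cells for antagonist activity at P2X purinoceptor 7 (Homo sapiens), read by FLIPR and calcium flux; a higher number here means a weaker inhibitor, a lower number a stronger inhibitor;
compound 2 `COc1ccc(C2(C(=O)NNc3cccc4ncccc34)CCCCC2)cc1`, 52.5 nM in this assay;
compound 3 `O=C(NNc1cccc2ncccc12)C1(c2ccccc2F)CCCCC1`, 191 nM in this assay.

Among these three, compound 3 gives the highest number, although it sits within the scatter of compound 1, while its gap to compound 2 lies beyond the scatter. Compound 4 `O=C(NNc1cccc2ncccc12)C1(c2cccc(F)c2)CCCCC1` is not yet measured; it differs from compound 3 by 3-fluorophenyl in place of 2-fluorophenyl on a saturated ring carbon. Within the data shown here, the only measured step on that same carbon is a 3.6-fold higher number from compound 2 to compound 3 (0.56 log units; beyond the scatter), which exchanged a quite different group; no measured step exchanges one fluorophenyl for another. With no direct guide, a change within the scatter is expected, if anything a slightly lower number. Compound 4 is therefore estimated at 150 nM, ranging from 60 nM to 400 nM, a step of a 1.3-fold lower number from compound 3 to compound 4 (0.10 log units; within the scatter) in this assay.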

Compound 4, half-maximal inhibitory concentration: 141 nM
Estimate against measurement, compound 4: 1.1-fold (0.03 log units) above; measured number inside the range.
By their numbers in this assay, from the lowest: compound 2; then compounds 4, 1 and 3 (each within the scatter of the next).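

In this assay, putting 3-fluorophenyl in place of 2-fluorophenyl on the saturated ring carbon gives a 1.4-fold lower number from compound 3 to compound 4 (0.13 log units; within the scatter) and so makes no clear difference between these two fluorophenyl groups. Putting 3-fluorophenyl in place of 4-methoxyphenyl gives a 2.7-fold higher number from compound 2 to compound 4 (0.43 log units; beyond the scatter) and so, like the step to the 2-fluorophenyl compound, leaves a real gap to compound 2. Nothing available here explains these results. Still open, going by these compounds, is whether 3-methoxyphenyl, 4-fluorophenyl or a phenyl ring carrying an amine on this carbon would match compound 2 or the fluorophenyl compounds.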